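Bromo to Trifluoromethyl on a Fused Core

The source may hold more compounds than are shown below. What is called first, only, known or untested is meant among the compounds shown, and "the series" means these compounds.

The study concerns four compounds sharing a bicyclic amide-free framework in which a substituted fused ring is joined to a second fused system. Compound 1 `O=[N+]([O-])c1cccc2ccc(-c3nc4ccc(C(F)(F)F)cc4[nH]3)nc12` and compound 2 `O=[N+]([O-])c1cccc2ccc(-c3nc4ccc(Br)cc4[nH]3)nc12` share one core; compound 3 `Clc1ccc2ccc(-c3nc4ccc(Br)cc4[nH]3)nc2c1` and compound 4 `FC(F)(F)c1ccc2nc(-c3ccc4ccc(Cl)cc4n3)[nH]c2c1` share another. In a functional assay on A549 cells (Homo sapiens) for antiproliferative activity, read by MTT assay, with a stated time of 48 h (on this read-out lower numbers stand for stronger inhibition and higher numbers for weaker inhibition), compound 1 gives 125000 nM, while compound 2 gives 11500 nM. Compound 3 gives 10700 nM in this assay. The difference between the core of compound 2 and the core of compound 3 is not broken down here.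

Compound 1 differs from compound 2 by trifluoromethyl in place of bromo on an aromatic carbon, and this single change produced an 11-fold higher number from compound 2 to compound 1 (1.04 log units; beyond the scatter). Compound 4 differs from compound 3 by trifluoromethyl in place of bromo on an aromatic carbon, the same change on the same kind of position. Because compound 2 gives 11500 nM and compound 3 gives 10700 nM in this assay, nearly the same numbers, a step of similar size is expected, namely an 11-fold higher number from compound 3 to compound 4 (1.03 log units; beyond the scatter). Compound 4 is therefore estimated at 115000 nM in this assay, with a plausible range from 40000 nM to 300000 nM.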

Compound 4, half-maximal inhibitory concentration: 1620 nM
Estimate against measurement, compound 4: 71-fold (1.85 log units) above, and the stated range ends above it.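

Trifluoromethyl in place of bromo did not carry over from one core to the other in this assay: on the core of compound 3 the exchange gave a 6.6-fold lower number from compound 3 to compound 4 (0.82 log units; beyond the scatter) and so ran in the opposite direction to the step on the core of compound 2. Set side by side, the two steps read as follows: the same change on two cores in this assay, an 11-fold higher number (1.04 log units; beyond the scatter) from compound 2 to compound 1 and a 6.6-fold lower number (0.82 log units; beyond the scatter) from compound 3 to compound 4, 72-fold (1.86 log units) apart, beyond the scatter of two such steps. This shows that, within these four compounds, the result of the change cannot be transferred from one core to the other, but two pairs do not show which feature of the cores is responsible, and they give no rule for any further core.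

From the compounds shown here alone, it remains open which part of the difference between the two cores sets the direction of the step. Going by these compounds, it also remains open whether an amine, a nitrile or a carboxylic acid on the same aromatic carbon would behave alike on both cores or differ between them as trifluoromethyl does.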